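Plasma protein binding: from compound 1 to compound 4

The source may hold more compounds than are shown below. What is called first, only, known or untested is meant among the compounds shown, and "the series" means these compounds.

Measured in an ADME assay on a cell-free system (plasma, Homo sapiens) for protein binding, read by LC-MS, with a stated time of 5 h, tested at 5 uM:
- Compound 1 `COc1cc(OCc2ccnc(N)c2Cl)cc2sc(N[C@@H]3CCCC[C@H]3O)nc12`: 98.7%
- Compound 2 `Nc1nccc(COc2cc(Cl)c3nc(N[C@@H]4CCCC[C@H]4O)sc3c2)c1Cl`: > 99% (a limit of the assay)
- Compound 3 `Nc1nccc(COc2cc(F)c3nc(N[C@@H]4CCCC[C@H]4O)sc3c2)c1Cl`: 98.6%

Compound 1 cannot be told apart from its nearest neighbour, with a 1.1-fold higher unbound fraction from compound 1 to compound 3 (0.03 log units; within the scatter). The other two steps, an at least 1.3-fold lower unbound fraction from compound 1 to compound 2 (0.11 log units; that floor lies within the scatter) and an at least 1.4-fold higher unbound fraction from compound 2 to compound 3 (0.14 log units; that floor lies within the scatter), are only floors, set by the limit of > 99% in this assay, at which 1 of the 3 values shown sits.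

Compound 4 `COc1cc(OCc2ccnc(N)n2)cc2sc(N[C@@H]3CCCC[C@H]3O)nc12` differs from compound 1 in one place: 2-aminopyrimidin-4-yl in place of 2-amino-3-chloropyridin-4-yl on a saturated chain carbon bound to an oxygen on an aromatic ring. Here 2-aminopyrimidin-4-yl stands in place of 2-amino-3-chloropyridin-4-yl on a saturated chain carbon bound to an oxygen on an aromatic ring. All three measured steps exchange a group on an aromatic carbon elsewhere, so none gives a direct size for this change. They bear on it only as a sign that the series has stayed high in this assay. Starting from compound 1 at 98.7%, a small move towards more free compound is expected, though this is a tentative call. The expected step is a 1.9-fold higher unbound fraction from compound 1 to compound 4 (0.28 log units; within the scatter). For compound 4 the estimated value is 97.5%, with an expected range of 94.5% to 98.9%.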

Compound 4, plasma protein binding: 77.1%
For compound 4 the middle estimate is 9.2-fold (0.96 log units) (unbound fraction) below the measured one, outside the stated range (below it).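

In this assay, 2-aminopyrimidin-4-yl in place of 2-amino-3-chloropyridin-4-yl gives an 18-fold higher unbound fraction from compound 1 to compound 4 (1.25 log units; beyond the scatter) on the saturated chain carbon bound to an oxygen on an aromatic ring. This is the only step shown that lies beyond the scatter, whereas the exchanges among methoxy, chloro and fluoro on an aromatic carbon stay within it or give floors that lie within it. The read-out therefore responds to this position in a way those exchanges did not show, though nothing measured here gives a cause for the step.

On these data alone, the change alters the ring hetero atoms and removes the chlorine together, so the share of each remains open. Also open, as far as these compounds go, is whether the step carries over to the cores of compound 2 and compound 3, and how an aliphatic amine or a carboxylic acid at this position would read.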